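Cyclohexyl on the ring amide nitrogen of compound 3

A few compounds are considered here, and "the series" means these few. Any claim that something is new, unique, unknown or untested is made for them only; others in the source may bear on it.

Three compounds of the series share one core and differ only in the group on the amide-type nitrogen in the ring. In an assay on HEK293 cells for positive allosteric modulation of metabotropic glutamate receptor 2 (Rattus norvegicus), read by thallium flux (on this read-out lower numbers stand for smaller maximal responses and higher numbers for larger maximal responses), compound 1 `O=C(O)c1cc(-c2cccc(COc3ccc4c(c3)CN(Cc3ccc(C(F)(F)F)cc3)C4=O)c2)ccc1Cl` gives 86.7%. Compound 2 `CC(C)N1Cc2cc(OCc3cccc(-c4ccc(Cl)c(C(=O)O)c4)c3)ccc2C1=O` gives 88.1%, and compound 3 `CC(C)CCN1Cc2cc(OCc3cccc(-c4ccc(Cl)c(C(=O)O)c4)c3)ccc2C1=O` gives 85.3%. Compound 3 has the smallest of the three numbers, but the gaps are slight: a number 1.4 percentage points lower from compound 1 to compound 3 (within the scatter) and a number 2.8 percentage points lower from compound 2 to compound 3 (within the scatter), with a number 1.4 percentage points higher from compound 1 to compound 2 (within the scatter) between the other two.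

Compound 4 `O=C(O)c1cc(-c2cccc(COc3ccc4c(c3)CN(C3CCCCC3)C4=O)c2)ccc1Cl` is not yet measured. It differs from compound 3 in one place: cyclohexyl in place of isopentyl on an amide-type nitrogen in a ring. All three measured steps swap one group for another on the same amide-type nitrogen, including a large aromatic group against small branched chains, and every one stayed within the scatter. Among the measured compounds shown here, no measured step concerns a saturated ring on this nitrogen, so the bearing of the earlier steps is indirect. On that basis no step beyond the scatter is expected here, in either direction.

For compound 4 the maximal response in this assay is estimated at 86%, with a range of 76% to 96%, which is expected to mean a number 0.7 percentage points higher from compound 3 to compound 4 (within the scatter).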

Compound 4, largest response reached (Emax), in percent of the reference or control that the assay uses: 63.3%
Compound 4: middle estimate off by 22.7 percentage points, on the high side, and the stated range ends above it.
By their numbers in this assay, from the lowest: compound 4; then compounds 3, 1 and 2 (each within the scatter of the next).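

Among the compounds shown here, on the amide-type nitrogen, cyclohexyl is the first group to move the maximal response in this assay beyond the scatter, with a number 22 percentage points lower from compound 3 to compound 4 (beyond the scatter) against isopentyl and a number 24.8 percentage points lower from compound 2 to compound 4 (beyond the scatter) against isopropyl and a number 23.4 percentage points lower from compound 1 to compound 4 (beyond the scatter) against 4-(trifluoromethyl)benzyl. The position is therefore not indifferent to its substituent, and among these four compounds the loss goes with a six-membered carbon ring bound directly to the nitrogen, not with carbon count, since isopentyl and cyclohexyl differ by a single carbon while the larger 4-(trifluoromethyl)benzyl group of compound 1 keeps its response level with that of compound 2 and compound 3. No measurement at hand accounts for this drop.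

On these data alone, it remains open whether the loss belongs to any saturated ring on this nitrogen or to this ring size alone, which cyclopentyl or cyclobutyl would separate. Cyclohexylmethyl would show whether one carbon between the ring and the nitrogen restores the response, and tetrahydropyranyl would show whether a ring oxygen changes the outcome.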